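The source may report more compounds than this note shows. Statements on the series, on what has been measured and on what is new or still open speak of the compounds shown alone.

Measured so far in an assay on HEK293 cells for negative allosteric modulation of metabotropic glutamate receptor 5 (Homo sapiens), read by FLIPR, with a stated time of 1 h; a lower number here means a stronger inhibitor, a higher number a weaker inhibitor:

Compound 1, `COc1ccccc1C#Cc1nc2c(s1)C(=O)NCC2`, gives > 10000 nM; this value is a limit of the assay, not a number.
Compound 2, `Fc1cccc(C#Cc2nc3c(s2)CN(C2CCOC2)CC3)c1`, gives 400 nM.
Compound 3, `O=C(C1CC1)N1CCc2nc(C#Cc3ccccc3)sc2C1`, gives 290 nM.

Compound 3 holds the lowest of the two numbers, but compound 2 sits within the usual scatter of it, so the two cannot be told apart. For the measured compounds named here, no pair of measured compounds differs in only one place, so no measured step guides what comes next. Compound 4, `O=C(C1CCCCC1)N1CCc2nc(C#Cc3ccccc3)sc2C1`, differs from compound 3 by cyclohexyl in place of cyclopropyl on a carbonyl carbon. With nothing measured on a change of this kind, a modest step in this assay seems most likely, in either direction and probably not beyond the scatter. The estimate for compound 4 is 400 nM, between 120 nM and 1300 nM. This corresponds to an expected step of a 1.4-fold higher number from compound 3 to compound 4 (0.14 log units; within the scatter).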

Compound 4, half-maximal inhibitory concentration: > 10000 nM
Compound 4 ended at the assay's limit; the forecaster's own chance of this, stated with the estimate: 10%; middle value at least 25-fold (1.39 log units) away from the limit.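

On a carbonyl carbon whose other neighbour is an amide-type nitrogen in a ring, this position proves sensitive to the size of the carbon ring: cyclohexyl in place of cyclopropyl gives an at least 34-fold higher number from compound 3 to compound 4 (1.53 log units; beyond the scatter) in this assay. The change adds only ring carbon, with no hydrogen-bond donor, acceptor or net charge entering or leaving. The value of compound 4 is a limit of the assay, not a number: the limit of > 10000 nM in this assay, at which 2 of the 4 values shown sit.

Still open, as far as these compounds go, is how cyclobutyl or cyclopentyl would read at this position. Also open, from the compounds shown here alone, is whether an amine on the cyclohexyl ring would give a measurable number.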